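This account rests on a few compounds, and the source may have more. Where it says the series, first, only, none or still open, it means among the compounds named here.

Measured in an assay on isolated protein for inhibition of DNA topoisomerase 1 (Homo sapiens), with a stated time of 15 min; a higher number here means a weaker inhibitor, a lower number a stronger inhibitor:
- compound 1 `NC[C@@H]1CCN(c2ccc3c(=O)c(C(=O)O)cn(Cc4ccc(-n5cccn5)cc4)c3c2)C1`: 61000 nM
- compound 2 `COc1c(N2CC[C@@H](CN)C2)c(F)cc2c(=O)c(C(=O)O)cn(Cc3cc(-c4ccccc4)no3)c12`: 178000 nM
- compound 3 `COc1c(NCCN)c(F)cc2c(=O)c(C(=O)O)cn(Cc3ccc(-c4ccccc4)cc3)c12`: in this assay compound 3 reaches only the limit > 200000 nM, a limit of the assay and not a number.

Among the two numbers shown, compound 1 stands lowest; compound 2 sits higher, and that gap lies beyond the usual scatter. One value of three is a limit (the limit of > 200000 nM in this assay, at which 1 of the 3 values shown sits). Compound 4 `NC[C@@H]1CCN(c2cc3c(cc2F)c(=O)c(C(=O)O)cn3Cc2ccc(-n3cccn3)cc2)C1` differs from compound 1 in one place: fluoro in place of hydrogen on an aromatic carbon. Within the data shown here, no pair of measured compounds differs in that single place, so the size of such a step is unknown here; no move beyond the scatter is expected in either direction in this assay. For compound 4 the estimate is 55000 nM (range 20000 nM to 160000 nM), which means an expected step of a 1.1-fold lower number from compound 1 to compound 4 (0.04 log units; within the scatter).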

Compound 4, half-maximal inhibitory concentration: 91600 nM
Beside the measured number, compound 4's estimate is 1.7-fold (0.22 log units) below it, and the stated range covers the measured number.
By their numbers in this assay, from the lowest: compounds 1, 4 and 2 (each within the scatter of the next, the first and the last beyond it). At a limit, above all of these: compound 3.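

In this assay, the series gains its first single-place comparison, with fluoro in place of hydrogen on the aromatic carbon ortho to the 3-(aminomethyl)pyrrolidin-1-yl group: a 1.5-fold higher number from compound 1 to compound 4 (0.18 log units; within the scatter). At this position, therefore, the hydrogen and fluoro compounds cannot be told apart in this measurement. Nothing measured here bears on the cause of this step.

On these data alone, whether chloro, methyl or an amine at this position would give a step beyond the scatter remains open. Also open, as far as these compounds go, is whether fluoro behaves alike with a piperazine in place of the 3-(aminomethyl)pyrrolidin-1-yl group.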